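The source may report more compounds than this note shows. Statements on the series, on what has been measured and on what is new or still open speak of the compounds shown alone.

Measured so far:
- compound 1 `CC(/C=C/CC(C)CCCC(C)C)=C\C(=O)OC(C)C` gives 7.15 in a physicochemical assay for lipophilicity; on this read-out higher numbers stand for higher lipophilicity and lower numbers for lower lipophilicity
- compound 2 `CC(/C=C/CC(C)CCCC(C)C)=C\C(=O)OC(C)(C)C` gives 7.56 in this assay

Compound 1 is the lower of the two (7.15) in this assay and compound 2 lies above it. Compound 3 `CC(/C=C/CC(C)CCCC(C)(C)OC(C)C)=C\C(=O)OC(C)C` has not yet been measured. It differs from compound 1 by isopropoxy in place of hydrogen on a saturated chain carbon bound to three saturated chain carbons. Among the measured compounds shown here, no measured step has isopropoxy entering. For the measured compounds named here, the only step available is a number 0.41 log units higher from compound 1 to compound 2 (beyond the scatter) (methyl in place of hydrogen, at another place), modest and beyond the scatter. This is weak guidance, so a modest rise in this assay is expected, though a change within the scatter remains possible. The expected step is a number 0.25 log units higher from compound 1 to compound 3 (within the scatter) on this read-out. For compound 3 the estimate is 7.4 with an expected range from 6.8 to 8 overall.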

Compound 3, partition coefficient: 6.9
Beside the measured number, compound 3's estimate is 0.50 log units above it; the range from low to high includes it.
By their numbers in this assay, from the lowest: compounds 3 and 1 (each within the scatter of the next); then compound 2.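

In this assay, isopropoxy in place of hydrogen on a saturated chain carbon bound to three saturated chain carbons gives a number 0.25 log units lower from compound 1 to compound 3 (within the scatter), so 4 heavy atoms, among them 1 hydrogen-bond acceptor, enter at this position without a step beyond the scatter. The methyl in place of hydrogen at another place gives a number 0.41 log units higher from compound 1 to compound 2 (beyond the scatter), so among these compounds the step beyond the scatter belongs to the smaller entering group and at a different place. No measurement at hand bears on the reason for either step.

From the compounds shown here alone, whether methoxy or a hydroxyl group at this same carbon would also stay within the scatter of compound 1 remains open. So does the outcome with an amine or a carboxylic acid there, which would show how far this position tolerates other groups.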